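Five-membered aryl swap: compound 2 to compound 3

The compounds below may be only part of what the source reports. "The series", "measured", "known", "first", "only" and "open" are said of these compounds alone.

Measured so far:
compound 1, `c1cncc(-c2ccccc2OCC2=NCCN2)c1`: 50.1 nM
compound 2, `c1c[nH]c(-c2ccccc2OCC2=NCCN2)c1`: 32.4 nM

In an assay for binding affinity to Alpha-1A adrenergic receptor (Homo sapiens) (a higher number here means a weaker inhibitor, a lower number a stronger inhibitor), compound 2 gives 32.4 nM and compound 1 gives 50.1 nM; the two are separated only by a 1.5-fold lower number from compound 1 to compound 2 (0.19 log units; within the scatter), so compound 2 stands level with compound 1 within the scatter. Compound 3, `Cc1ccoc1-c1ccccc1OCC1=NCCN1`, differs from compound 2 by 3-methylfuran-2-yl in place of 1H-pyrrol-2-yl on an aromatic carbon. For the measured compounds named here, the single measured step also exchanged one five-membered aromatic ring for another at this carbon and stayed within the scatter; no measured step tests the loss of the donor. The expectation is therefore no step beyond the scatter, a 1.2-fold higher number from compound 2 to compound 3 (0.09 log units; within the scatter). Compound 3 is estimated at 40 nM in this assay, with a range of 14 nM to 115 nM.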

Compound 3, half-maximal inhibitory concentration: 34.7 nM
For compound 3 the middle estimate is 1.2-fold (0.06 log units) above the measured one; low and high end bracket the measured number.
By their numbers in this assay, from the lowest: compounds 2, 3 and 1 (each within the scatter of the next).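

In this assay, 3-methylfuran-2-yl in place of 1H-pyrrol-2-yl gives a 1.1-fold higher number from compound 2 to compound 3 (0.03 log units; within the scatter) and in place of pyridin-3-yl gives a 1.4-fold lower number from compound 1 to compound 3 (0.16 log units; within the scatter) at this aromatic carbon. The hydrogen-bond donor of 1H-pyrrol-2-yl is therefore lost here with no step beyond the scatter, although this single change also swaps the ring hetero atom and adds a methyl. No measured property bears on these steps.

Still open, from the compounds shown here alone, is how an amine or a carboxylic acid on this carbon would read, and what the methyl contributes apart from the furan ring.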